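Benzyl in place of benzothiophenyl on the shared core

A few compounds are considered here, and "the series" means these few. Any claim that something is new, unique, unknown or untested is made for them only; others in the source may bear on it.

The measured compounds:
compound 1 `CCOC(=O)c1cnc(C)nc1NN1C(=O)C=C(C)C1=O` gives 16000 nM in a functional assay on Jurkat cells for inhibition of nuclear factor NF-kappa-B complex (Homo sapiens); on this read-out lower numbers stand for stronger inhibition and higher numbers for weaker inhibition
compound 2 `CCOC(=O)c1cnc(-c2cccc([N+](=O)[O-])c2)nc1NN1C(=O)C=C(C)C1=O` gives 7000 nM in this assay
compound 3 `CCOC(=O)c1cnc(-c2cc3ccccc3s2)nc1NN1C(=O)C=C(C)C1=O` gives 4000 nM in this assay

Compound 3 shows the lowest number of the three, yet the gap to compound 2 is within the scatter (a 1.8-fold lower number from compound 2 to compound 3 (0.24 log units; within the scatter)), so the two cannot be ranked; only the gap to compound 1 is beyond it (a 4.0-fold lower number from compound 1 to compound 3 (0.60 log units; beyond the scatter)). Compound 4 `CCOC(=O)c1cnc(Cc2ccccc2)nc1NN1C(=O)C=C(C)C1=O` is the next compound, differing from compound 3 in one way: benzyl in place of 1-benzothiophen-2-yl on an aromatic carbon.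

Within the data shown here, two measured steps bear on this. Replacing methyl with a larger aromatic group lowered the number modestly in both cases, a 2.3-fold lower number from compound 1 to compound 2 (0.36 log units; beyond the scatter) and a 4.0-fold lower number from compound 1 to compound 3 (0.60 log units; beyond the scatter). Benzyl, with one aromatic ring and no acceptor, stands in size somewhere between methyl and the groups of compounds 2 and 3. Compound 4 is therefore expected to give a somewhat higher number in this assay than compound 3, by about a 2.0-fold higher number from compound 3 to compound 4 (0.30 log units; within the scatter), close to the edge of the scatter. The estimate for compound 4 is 8000 nM, with a range from 3000 nM to 20000 nM.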

Compound 4, half-maximal inhibitory concentration: 7000 nM
Estimate against measurement, compound 4: 1.1-fold (0.06 log units) above; measured number inside the range.
By their numbers in this assay, from the lowest: compounds 3, 2 and 4 (each within the scatter of the next); then compound 1.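

In this assay, the benzyl group cannot be told apart from the 1-benzothiophen-2-yl group (a 1.8-fold higher number from compound 3 to compound 4 (0.24 log units; within the scatter)) or from the 3-nitrophenyl group (no change at the digits printed from compound 2 to compound 4 (within the scatter)). Among these three groups, then, neither a ring bonded directly to the shared core nor a hydrogen-bond acceptor in the group is needed to reach this level. Benzyl also stands clearly apart from methyl (a 2.3-fold lower number from compound 1 to compound 4 (0.36 log units; beyond the scatter)), so the lower number seen with large aromatic groups at this place also appears when one carbon separates the ring from the core.

As far as these compounds go, it remains open whether a longer chain such as 2-phenylethyl would keep this level at the same place. It is equally open how an amine or a carboxylic acid there would read out, and nothing shown explains why these three groups fall so close together.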